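Swapping the acyl group on the piperazine amide

The source may hold more compounds than are shown below. What is called first, only, known or untested is meant among the compounds shown, and "the series" means these compounds.

Measured so far:
Compound 1 `Cc1cccc(Cn2c(CN3CCN(C(=O)C4CCCC4)CC3)nc3ccccc32)c1`: 67.5%
Compound 2 `O=C(C1CC1)N1CCN(Cc2nc3ccccc3n2Cc2ccccc2C(F)(F)F)CC1`: 56.3%
Compound 3 `O=C(C1CC1)N1CCN(Cc2nc3ccccc3n2Cc2ccc(F)cc2)CC1`: 32.7%

In an assay on isolated protein for inhibition of aldehyde dehydrogenase 1A1 (Homo sapiens), read by spectrophotometry, tested at 10 uM (on this read-out higher numbers stand for more inhibition at the one concentration tested (going by the name of the read-out) and lower numbers for less inhibition), compound 1 gives the highest of the three numbers, with compound 2 next at 56.3% and compound 3 furthest away at 32.7%; both gaps to compound 1 lie beyond the scatter. The one step shown among the measured compounds, a number 23.6 percentage points lower from compound 2 to compound 3 (beyond the scatter), concerns the group on the saturated chain carbon bound to the aromatic nitrogen and not the amide side.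

Compound 4 `Cc1ccc(C(=O)N2CCN(Cc3nc4ccccc4n3Cc3cccc(C)c3)CC2)cc1` differs from compound 1 in one place: 4-methylphenyl in place of cyclopentyl on a carbonyl carbon. No measured step touches this carbonyl carbon, so no shown pair bears directly on the change. With nothing in the data pointing either way, the step of a number 7.5 percentage points lower from compound 1 to compound 4 (within the scatter) is expected to stay within the scatter, and compound 4 is estimated at 60%, between 35% and 80%.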

Compound 4, a percentage reported as inhibition, at one concentration (the size of the read-out at that concentration, not a potency): 64.9%
Compound 4: middle estimate off by 4.9 percentage points, on the low side; low and high end bracket the measured number.
By their numbers in this assay, from the lowest: compound 3; then compounds 2, 4 and 1 (each within the scatter of the next, the first and the last beyond it).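

For the compounds shown here, this is the first step measured at the carbonyl carbon: in this assay, 4-methylphenyl in place of cyclopentyl gives a number 2.6 percentage points lower from compound 1 to compound 4 (within the scatter), so the two acyl groups cannot be told apart at this single concentration. A six-membered aromatic ring of 7 heavy atoms can therefore stand on this carbonyl carbon in place of a five-membered non-aromatic ring of 5 heavy atoms without a change beyond the scatter, at least with the rest of compound 1 held fixed. Nothing available accounts for this result.

The compounds shown leave open whether a group carrying an amine or a carboxylic acid, or a longer open chain, would read the same on this carbonyl carbon. They also leave open whether the same holds with 2-(trifluoromethyl)phenyl or 4-fluorophenyl on the other side of the molecule.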